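Oxazole attachment point on the acid-bearing chain carbon

This account rests on a few compounds, and the source may have more. Where it says the series, first, only, none or still open, it means among the compounds named here.

Compound 2 `Cc1nc(-c2ccc(C(F)(F)F)cc2)sc1COc1ccc([C@H](CC(=O)O)c2ncco2)cc1` gives 69 nM in an assay on CHO cells for agonist activity at Free fatty acid receptor 1 (Homo sapiens), read by calcium flux; a higher number here means that more compound is needed for the effect, a lower number that less compound is needed. Compound 1 `Cc1nc(-c2ccc(C(F)(F)F)cc2)sc1COc1ccc([C@H](CC(=O)O)c2nccn2C)cc1` gives 73 nM in this assay, and the step of a 1.1-fold lower number from compound 1 to compound 2 (0.02 log units; within the scatter) shows the two numbers sit together. Compound 3 `Cc1nc(-c2ccc(C(F)(F)F)cc2)sc1COc1ccc([C@H](CC(=O)O)c2cnco2)cc1` is not yet measured; it differs from compound 2 by 1,3-oxazol-5-yl in place of 1,3-oxazol-2-yl on a saturated chain carbon bound to an aromatic carbon and a saturated chain carbon. Among the measured compounds shown here, the only measured step bearing on this position is a 1.1-fold lower number from compound 1 to compound 2 (0.02 log units; within the scatter), which exchanged one azole for another at the same chain carbon and stayed flat, so a different ring at this place has so far produced no shift beyond the scatter. For the measured compounds named here, no measured step moves the same ring to a different attachment atom, so the range is kept wide. For compound 3 the expected step is a 1.4-fold higher number from compound 2 to compound 3 (0.14 log units; within the scatter), small and without a clear direction. Compound 3 is estimated at 95 nM, with a range from 35 nM to 280 nM.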

Compound 3, half-maximal effective concentration: 57 nM
Estimate against measurement, compound 3: 1.7-fold (0.22 log units) above, within the range that was stated.
By their numbers in this assay, from the lowest: compounds 3, 2 and 1 (each within the scatter of the next).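

Shifting the attachment atom of the same oxazole ring on this saturated chain carbon does not separate the two isomers in this assay (a 1.2-fold lower number from compound 2 to compound 3 (0.08 log units; within the scatter)), so the choice between 1,3-oxazol-2-yl and 1,3-oxazol-5-yl is not resolved by this read-out. Set against the 1-methyl-1H-imidazol-2-yl group, 1,3-oxazol-5-yl also stays within the scatter (a 1.3-fold lower number from compound 1 to compound 3 (0.11 log units; within the scatter)), and all three azoles now sit together at this place. No measured evidence is available to account for this result.

From the compounds shown here alone, whether any group at this chain carbon can move the number beyond the scatter remains open. The compounds shown hold only five-membered azole rings here, so they give no reading for a phenyl ring, a pyridine ring or a primary amide at this place.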